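This account rests on a few compounds, and the source may have more. Where it says the series, first, only, none or still open, it means among the compounds named here.

Compound 1 `CC(C)c1ccc(-c2nc(SCc3cn(CC(=O)NC(=O)Nc4ccccn4)nn3)nc(Nc3cccc(C(F)(F)F)c3)c2C#N)cc1` gives > 64000 nM in a functional assay on MGC-803 cells (Homo sapiens) for inhibition, read by MTT assay, with a stated time of 72 h (a higher number here means a weaker inhibitor, a lower number a stronger inhibitor), which is a limit of the assay and not a number.
Compound 2 `Cc1ccc(-c2nc(SCc3cn(CC(=O)NC(=O)Nc4ccccn4)nn3)nc(Nc3cccc(C(F)(F)F)c3)c2C#N)cc1` gives 7580 nM in this assay.
Compound 3 `CC(C)c1ccc(Nc2nc(SCc3cn(CC(=O)NC(=O)Nc4ccccn4)nn3)nc(-c3ccc(Cl)cc3)c2C#N)cc1` gives 16900 nM in this assay.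

Compounds 1 and 2 share a core and differ in one place: methyl in place of isopropyl on an aromatic carbon. Across that change the number fell, an at least 8.4-fold lower number from compound 1 to compound 2 (0.92 log units; beyond the scatter), though the size of the step is open at its upper end because compound 1 sits at the limit (the limit of > 64000 nM in this assay, at which 1 of the 3 values shown sits). Compound 3 stands highest of the two numbers given, and its nearest neighbour is compound 2, whose number is lower by a gap beyond the usual scatter. How the core of compound 3 differs from that of compound 1 is not broken down here.

Compound 4 `Cc1ccc(Nc2nc(SCc3cn(CC(=O)NC(=O)Nc4ccccn4)nn3)nc(-c3ccc(Cl)cc3)c2C#N)cc1` has not been measured in this assay. It differs from compound 3 by methyl in place of isopropyl on an aromatic carbon, the same change that separates compound 1 from compound 2, here made on the (4-isopropylphenyl)amino group, which becomes (4-methylphenyl)amino, rather than on 4-isopropylphenyl alone. Among the measured compounds shown here, the step is expected to run in the same direction as an at least 8.4-fold lower number from compound 1 to compound 2 (0.92 log units; beyond the scatter) but to be smaller, a 2.8-fold lower number from compound 3 to compound 4 (0.45 log units; beyond the scatter), since only one example of the change is known and that one is bounded by a limit (the limit of > 64000 nM in this assay, at which 1 of the 3 values shown sits). Compound 4 is therefore estimated at 6000 nM, with a likely range from 2500 nM to 15000 nM.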

Compound 4, half-maximal inhibitory concentration: 24000 nM
The estimate for compound 4 lay 4.0-fold (0.60 log units) below the measured number; measured number outside the range, above it.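

On the core of compound 3, putting methyl in place of isopropyl, which turns (4-isopropylphenyl)amino into (4-methylphenyl)amino, gave a 1.4-fold higher number from compound 3 to compound 4 (0.15 log units; within the scatter) in this assay, so on this core the change has no effect that can be told from the scatter. Set beside the step on the core of compound 1, the same change does not carry over from one core to the other with the same size: the same change on two cores in this assay, an at least 8.4-fold lower number (0.92 log units; beyond the scatter) from compound 1 to compound 2 and a 1.4-fold higher number (0.15 log units; within the scatter) from compound 3 to compound 4, at least 11-fold (1.07 log units) apart, beyond the scatter of two such steps. This does not show which feature of the two cores sets the steps apart, and two examples fix no rule for the series, the more so as compound 1 stands at a limit of the assay and not a number, which leaves the first step open at its upper end: the limit of > 64000 nM in this assay, at which 1 of the 4 values shown sits.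

The compounds shown leave open how the (4-isopropylphenyl)amino place on the core of compound 3 would respond to groups other than these two, such as a methoxy group, an amine or a carboxylic acid. They also leave open how the same change from isopropyl to methyl would run on a third core, and so which of the two steps would be the more typical one.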